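Working notes: triazolyl in place of methylpiperazinyl

The compounds below may be only part of what the source reports. "The series", "measured", "known", "first", "only" and "open" are said of these compounds alone.

Among the measured compounds shown here, compound 2 `CC(=O)N1N=C(c2ccc(N3CCN(C)CC3)cc2)CC1c1ccc(N(C)C)cc1` gives -1% in a functional assay on MDA-MB-231 cells (Homo sapiens) for inhibition, read by sulforhodamine B assay, tested at 10 uM (on this read-out lower numbers stand for less inhibition and higher numbers for more inhibition at the one concentration tested (going by the name of the read-out)), the lowest of the two numbers so far; the nearest, compound 1 `CN(C)c1ccc(C2CC(c3ccc(-n4cncn4)cc3)=NN2)cc1`, gives 7%, a gap within the scatter. Compound 3 `CC(=O)N1N=C(c2ccc(-n3cncn3)cc2)CC1c1ccc(N(C)C)cc1` differs from compound 2 by 1H-1,2,4-triazol-1-yl in place of 4-methylpiperazin-1-yl on an aromatic carbon. For the measured compounds named here, no step between measured compounds is available, and compound 1, which carries the same triazolyl group, shows inhibition that stays within the scatter of compound 2. A step of a number 5 percentage points higher from compound 2 to compound 3 (within the scatter) is expected, none beyond the scatter. Compound 3 is expected at about 4%, with a range from -8% to 16%.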

Compound 3, a percentage reported as inhibition, at one concentration (the size of the read-out at that concentration, not a potency): 7.4%
Compound 3: the middle estimate sits 3.4 percentage points below what was measured, within the range that was stated.
By their numbers in this assay, from the lowest: compounds 2, 1 and 3 (each within the scatter of the next).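

a number 8.4 percentage points higher from compound 2 to compound 3 (within the scatter) in this assay comes with 1H-1,2,4-triazol-1-yl in place of 4-methylpiperazin-1-yl on the aromatic carbon, and a number 0.4 percentage points higher from compound 1 to compound 3 (within the scatter) comes with acetyl in place of hydrogen on the ring amine nitrogen. Both steps lie within the scatter, so neither change separates these compounds at the one concentration tested. No evidence on the cause of either step is available.

Open, on these data alone, is whether a carboxylic acid or a morpholin-4-yl group on this aromatic carbon would give a step beyond the scatter. The same holds for a longer acyl chain, such as butanoyl, on the ring nitrogen.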